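The source may hold more compounds than are shown below. What is called first, only, known or untested is meant among the compounds shown, and "the series" means these compounds.

In an assay on U2OS cells for inhibition of secreted frizzled-related protein 1 (Homo sapiens), read by a luciferase reporter, with a stated time of 18 h (on this read-out lower numbers stand for an effect already at smaller amounts and higher numbers for an effect only at larger amounts of compound), compound 1 `O=C(c1ccccc1)N1CCC(NS(=O)(=O)c2cc(S(=O)(=O)c3ccccc3)ccc2C(F)(F)F)CC1` gives 250 nM, and compound 2 `CC(C)(C)OC(=O)N1CCC[C@H]1C(=O)N1CCC(NS(=O)(=O)c2cc(S(=O)(=O)c3ccccc3)ccc2C(F)(F)F)CC1` gives 60 nM, the lowest of the two numbers recorded; the step of a 4.2-fold lower number from compound 1 to compound 2 (0.62 log units; beyond the scatter) lies beyond the scatter. Compound 3 `CC(C)(C)OC(=O)N1CCC[C@@H]1C(=O)N1CCC(NS(=O)(=O)c2cc(S(=O)(=O)c3ccccc3)ccc2C(F)(F)F)CC1` differs from compound 2 only in configuration: the two compounds have the same atoms and bonds and differ only in configuration as drawn: 1 of 1 stereo elements differ; a stereocentre at a saturated ring carbon is drawn S in compound 2 and R in compound 3. Among the compounds with values here, no measured step touches a stereocentre, so the step of a 4.2-fold lower number from compound 1 to compound 2 (0.62 log units; beyond the scatter), which exchanged a whole group on a carbonyl carbon, offers no direct guide here. Compound 3 is therefore expected to show a somewhat higher number, a step of a 2.5-fold higher number from compound 2 to compound 3 (0.40 log units; beyond the scatter), with wide uncertainty. The estimate for compound 3 is 150 nM, within a range from 40 nM to 600 nM.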

Compound 3, half-maximal effective concentration: 210 nM
Compound 3: middle estimate off by 1.4-fold (0.15 log units), on the low side; low and high end bracket the measured number.
By their numbers in this assay, from the lowest: compound 2; then compounds 3 and 1 (each within the scatter of the next).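

In this assay, within the data shown here, the configuration at the saturated ring carbon proves to matter, a point no earlier pair could show: a 3.5-fold higher number from compound 2 to compound 3 (0.54 log units; beyond the scatter). With this carbon drawn R, the 1-(tert-butoxycarbonyl)pyrrolidin-2-yl group no longer stands apart from phenyl: a 1.2-fold lower number from compound 1 to compound 3 (0.08 log units; within the scatter), so the earlier step holds only for the S form. The shift belongs to the stereocentre alone because of one plain structural point: the fact that compounds 2 and 3 differ only in the configuration as drawn

On these data alone, whether the gap between S and R persists with a free amine or an acetyl group in place of tert-butoxycarbonyl stays open.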